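Trading a Benzyl for Hydrogen on the Amine Nitrogen

The source may report more compounds than this note shows. Statements on the series, on what has been measured and on what is new or still open speak of the compounds shown alone.

Three measured compounds share one core and differ at an ester-bearing amine nitrogen and on the aniline ring. In a functional assay on HepG2 cells (Homo sapiens) for antiproliferative activity, read by MTT assay, with a stated time of 48 h (a higher number here means a weaker inhibitor, a lower number a stronger inhibitor), compound 3 `CCOC(=O)CN(Cc1ccccc1)c1nc(Nc2cccc(OC)c2)ncc1[N+](=O)[O-]` gives 27600 nM, the lowest of the two numbers recorded. Compound 2 `COC(=O)CN(C)c1nc(Nc2cccc(OC)c2)ncc1[N+](=O)[O-]` gives 73400 nM, a gap from compound 3 that lies beyond the usual scatter. Compound 1 `CCOC(=O)CNc1nc(Nc2ccccc2)ncc1[N+](=O)[O-]` reaches only the assay limit of > 100000 nM, a limit rather than a number. Compound 4 `CCOC(=O)CNc1nc(Nc2cccc(OC)c2)ncc1[N+](=O)[O-]` has not yet been measured. It differs from compound 3 in one place: hydrogen in place of benzyl on a nitrogen on an aromatic ring. Compound 1 carries hydrogen at the same nitrogen, though with a different aniline ring, and sits at the limit (the limit of > 100000 nM in this assay, at which 1 of the 3 values shown sits). A weakening step is therefore expected, estimated at a 4.3-fold higher number from compound 3 to compound 4 (0.64 log units; beyond the scatter). Compound 4 is expected to give about 120000 nM, within a range from 40000 nM to 300000 nM, and may well return only a limit.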

Compound 4, half-maximal inhibitory concentration: > 100000 nM
Compound 4: only a limit was reported; the forecaster's own chance of this, stated with the estimate: 60%; the middle value is on the limit's open side.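

Hydrogen in place of benzyl on this nitrogen, with the rest of the molecule unchanged, gives the first direct reading at this position in this assay: an at least 3.6-fold higher number from compound 3 to compound 4 (0.55 log units; beyond the scatter). The change from ((methoxycarbonyl)methyl)(methyl)amino to ((ethoxycarbonyl)methyl)amino gives an at least 1.3-fold higher number from compound 2 to compound 4 (0.13 log units; that floor lies within the scatter), so this floor alone cannot separate the two compounds. Compound 1 and compound 4, the two with hydrogen on this nitrogen, each stop at a limit of the assay, and the step between them cannot be read: the limit of > 100000 nM in this assay, at which 2 of the 4 values shown sit.

Still open, from the compounds shown here alone, is whether the aromatic ring of the benzyl group matters or whether any carbon group on this nitrogen would serve, a question that a cyclohexylmethyl group alongside the ethyl ester could address. Going by these compounds, how a carboxylic acid in place of the ester would read also remains unknown.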